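A few compounds are considered here, and "the series" means these few. Any claim that something is new, unique, unknown or untested is made for them only; others in the source may bear on it.

Of the compounds shown here, three share a common core and have been measured in an assay on isolated protein with Bile acid receptor (Homo sapiens) as the target; a higher number here means that more compound is needed for the effect, a lower number that less compound is needed. Compound 1, `COC(=O)/C=C/c1cccc(N(Cc2ccc(/C=C/c3c(F)cccc3F)cc2)C(=O)C(C)C)c1`, gives 108 nM in this assay. Compound 2, `COC(=O)/C=C/c1cccc(N(Cc2ccc(/C=C/c3c(C)cc(C)cc3C)cc2)C(=O)NC(C)C)c1`, gives 431 nM. Compound 3, `COC(=O)/C=C/c1cccc(N(Cc2ccc(/C=C/c3cccc(F)c3)cc2)C(=O)C2CCCCC2)c1`, gives 86 nM, the lowest of the three numbers; its separation from compound 1 lies within the usual scatter, so no order between those two can be claimed, whereas compound 2 stands beyond the scatter from compound 3.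

Compound 4, `COC(=O)/C=C/c1cccc(N(Cc2ccc(-c3ccc(SC)cc3)cc2)C(=O)C2CCCCC2)c1`, has not yet been measured. It differs from compound 3 in one place: 4-(methylsulfanyl)phenyl in place of 2-(3-fluorophenyl)ethenyl on an aromatic carbon. For the measured compounds named here, no pair among the measured compounds differs in only one place, so there is no measured step on which to rest a prediction, and the change from a 2-(3-fluorophenyl)ethenyl group to a 4-(methylsulfanyl)phenyl group is not paralleled anywhere in the set.

In this assay the author expects compound 4 to give a somewhat higher number than compound 3, with a step of a 2.3-fold higher number from compound 3 to compound 4 (0.37 log units; beyond the scatter), though one that may not exceed the scatter. The estimate for compound 4 in this assay is 200 nM, with a plausible range from 60 nM to 700 nM.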

Compound 4, half-maximal effective concentration: 69 nM
Estimate against measurement, compound 4: 2.9-fold (0.46 log units) above, within the range that was stated.
By their numbers in this assay, from the lowest: compounds 4, 3 and 1 (each within the scatter of the next); then compound 2.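

In this assay, putting a 4-(methylsulfanyl)phenyl group in place of the 2-(3-fluorophenyl)ethenyl group, on an aromatic carbon para to a large group, gives a 1.2-fold lower number from compound 3 to compound 4 (0.10 log units; within the scatter), so no order can be claimed between the two. All three earlier compounds carried an ethenyl link at this place, and so could not show what happens without it; this pair shows that a group with no double bond outside aromatic rings and no fluorine, but with a sulfur, can stand here and keep the number within the scatter of compound 3. Nothing available on the properties of these two groups speaks to why their numbers lie so close.

From the compounds shown here alone, it remains open whether the sulfur matters at all: a methoxy group or a plain hydrogen in place of the methylsulfanyl group would address that. Going by these compounds, it is also open whether the 4-(methylsulfanyl)phenyl group would give a similar result with the carbonyl substituents of compound 1 or compound 2, or with a carboxylic acid in place of the methyl ester.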